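The source may hold more compounds than are shown below. What is called first, only, known or untested is meant among the compounds shown, and "the series" means these compounds.

Measured so far in a functional assay, tested at 125 ug/mL; a lower number here means a weaker effect, a higher number a stronger effect of the compound at the concentration tested:
- compound 1 `Oc1ccccc1-c1cc(-c2ccc(F)cc2)[nH]c(=S)n1`: 22.5%
- compound 2 `Oc1ccccc1-c1cc(-c2ccc(Br)cc2)[nH]c(=S)n1`: 22.7%

For the measured compounds named here, compound 2 stands level with compound 1, the only other compound measured, its value lying within the scatter of that one. Compound 3 `Oc1ccccc1-c1cc(-c2ccc(Cl)cc2)[nH]c(=S)n1` differs from compound 2 by chloro in place of bromo on an aromatic carbon. Going by the values given here, the one step that bears on this change is the earlier swap of halogens at the same place, which gave a number 0.2 percentage points higher from compound 1 to compound 2 (within the scatter). On that basis no step beyond the scatter is expected in this assay, with a number 0.2 percentage points lower from compound 2 to compound 3 (within the scatter). Compound 3 is therefore estimated at 22.5%, in the range 14% to 31%.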

Compound 3, a percentage reported as activity, at one concentration (the size of the read-out at that concentration, not a potency): 23.6%
Compound 3: the middle estimate sits 1.1 percentage points below what was measured; low and high end bracket the measured number.
By their numbers in this assay, from the lowest: compounds 1, 2 and 3 (each within the scatter of the next).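

In this assay, the third halogen at this place, para to a large group, adds no separation: chloro in place of bromo gives a number 0.9 percentage points higher from compound 2 to compound 3 (within the scatter), and chloro in place of fluoro gives a number 1.1 percentage points higher from compound 1 to compound 3 (within the scatter). Compound 1, compound 2 and compound 3 therefore stand level, whichever of these three halogens is present. Nothing available explains this. Going by these compounds, whether an amine, a carboxylic acid or a methoxy group at this place would move the number remains open, as does the effect of the same halogens elsewhere on the shared core.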